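A few compounds are considered here, and "the series" means these few. Any claim that something is new, unique, unknown or untested is made for them only; others in the source may bear on it.

Among the compounds with values here, compound 1 `Cc1c(OCCCCOc2ccc(C(=O)O)cc2)ccc(C(=O)CC2CCCC2)c1O` and compound 2 `CCC(=O)c1ccc(OCCCCOc2cc(C(=O)O)ccc2OC)c(C)c1O` are the two measured members of this set. In an assay on HEK293 cells for positive allosteric modulation of metabotropic glutamate receptor 3 (Rattus norvegicus), read by thallium flux, with a stated time of 2.5 min (on this read-out lower numbers stand for an effect already at smaller amounts and higher numbers for an effect only at larger amounts of compound), compound 1 gives only a limit of the assay, > 10000 nM. Compound 2 gives 6360 nM in this assay, the only actual number shown and hence the sole anchor for any step. The remaining value is that of compound 1: the limit of > 10000 nM in this assay, at which 1 of the 2 values shown sits. Compound 3 `CCCC(=O)c1ccc(OCCCCOc2cc(C(=O)O)ccc2OC)c(C)c1O` has not yet been measured in this assay. It differs from compound 2 by methyl in place of hydrogen on a saturated chain carbon, two bonds along the chain from a carbonyl carbon. Within the data shown here, no measured pair shows this change, so its size in this assay is unknown; a shift of this kind is expected to leave compound 3 close to compound 2, not beyond the scatter. The expected step from compound 2 to compound 3 is a 1.4-fold lower number from compound 2 to compound 3 (0.15 log units; within the scatter). Compound 3 is therefore estimated at 4500 nM, with a range from 1500 nM to 15000 nM.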

Compound 3, half-maximal effective concentration: 496 nM
Estimate against measurement, compound 3: 9.1-fold (0.96 log units) above; the measured number lies below the stated range.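

In this assay the change of propanoyl to propylcarbonyl gives a 13-fold lower number from compound 2 to compound 3 (1.11 log units; beyond the scatter) and makes this saturated chain carbon, two bonds along the chain from a carbonyl carbon, the first position in the set where a single change is seen to move the read-out. Within the data shown here, one added methyl, a single carbon with no ring and no net charge, is enough for a step of this size, which the earlier compounds could not show as they offered no pair differing in one place. Nothing among the data shown accounts for the size of this step.

As far as these compounds go, it remains open whether a longer chain, such as butanoyl or pentanoyl, would carry the step further or reverse it. From the compounds shown here alone, it is equally open whether a hydroxyl group or an amine at this carbon would act as the methyl does.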